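Swapping a Benzimidazole for Fluorophenyl: Solubility Outlook

The source may hold more compounds than are shown below. What is called first, only, known or untested is meant among the compounds shown, and "the series" means these compounds.

Compound 1, `CNC(=O)c1ccc(=O)n(Cc2cc(Br)ccc2F)c1`, is reported only as a limit in a physicochemical assay for solubility (a higher number here means a more soluble compound, a lower number a less soluble compound), namely >= 143 ug/mL.
Compound 2, `CNC(=O)c1cc(C(=O)NC2CC2)cn(Cc2ccc3nc[nH]c3c2)c1=O`, is likewise reported only as a limit in this assay, namely >= 163 ug/mL.

Compound 2 therefore stands at a limit rather than a number in this assay, as does compound 1, so the two cannot be ranked against each other. Compound 3, `CNC(=O)c1cc(C(=O)NC2CC2)cn(Cc2ccccc2F)c1=O`, differs from compound 2 in one place: 2-fluorophenyl in place of 1H-benzimidazol-6-yl on a saturated chain carbon bound to an aromatic nitrogen. Within the data shown here, no measured pair isolates this change. The step expected from compound 2 to compound 3 in this assay is an at least 1.0-fold lower number from compound 2 to compound 3 (0.03 log units; that floor lies within the scatter), no larger than the usual scatter. Compound 3 is accordingly estimated at 150 ug/mL, within 60 ug/mL to 350 ug/mL.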

Compound 3, solubility: >= 145 ug/mL
Compound 3 gave a limit, no number (the forecaster's own chance of this, stated with the estimate: 60%); the middle value lies beyond the limit too.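

Among these compounds, compound 2 and compound 3 are both reported only as limits in this assay, so no step between them can be read. The compounds shown leave open whether 2-fluorophenyl in place of 1H-benzimidazol-6-yl changes solubility at all.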